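A few compounds are considered here, and "the series" means these few. Any claim that something is new, unique, unknown or untested is made for them only; others in the source may bear on it.

Compound 1 `Cc1ccc(-n2cc(COc3ccc(/C=C/C(=O)c4cc5c(cc4O)OC(C)(C)CC5)cc3)nn2)cc1Br` and compound 2 `Cc1ccc(-n2cc(COc3ccc(/C=C/C(=O)c4ccc5c(c4O)CCC(C)(C)O5)cc3)nn2)cc1Br` carry the same atoms joined differently; the difference between their two cores is not broken down here. In a functional assay on HepG2 cells (Homo sapiens) for antiproliferative activity, read by MTT assay (a higher number here means a weaker inhibitor, a lower number a stronger inhibitor), compound 1 gives 117000 nM, and compound 2 gives 110000 nM; the two numbers lie within the usual scatter of each other, so no order is read from them. Compound 3 `CC1(C)CCc2cc(C(=O)/C=C/c3ccc(OCc4cn(Cc5ccc([N+](=O)[O-])cc5)nn4)cc3)c(O)cc2O1` is compound 1 after one change: 4-nitrobenzyl in place of 3-bromo-4-methylphenyl on an aromatic nitrogen. In this assay compound 3 gives 109000 nM, and the step from compound 1 to compound 3 is a 1.1-fold lower number from compound 1 to compound 3 (0.03 log units; within the scatter), a change that did not move the read-out beyond the scatter. Compound 2 and compound 3 likewise sit within the scatter of each other.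

Compound 4 `CC1(C)CCc2c(ccc(C(=O)/C=C/c3ccc(OCc4cn(Cc5ccc([N+](=O)[O-])cc5)nn4)cc3)c2O)O1` is the corresponding change made on the core of compound 2: 4-nitrobenzyl in place of 3-bromo-4-methylphenyl on an aromatic nitrogen. The place of the change is worded identically in both cases, so it is taken as the same change on a different core. Among the measured compounds shown here, the only measured precedent, a 1.1-fold lower number from compound 1 to compound 3 (0.03 log units; within the scatter), lay within the scatter, and none of the three measured numbers stands apart from the others. On that basis only a small step is expected in this assay, about a 1.0-fold lower number from compound 2 to compound 4 (0.02 log units; within the scatter). Compound 4 is accordingly estimated at 105000 nM in this assay, with a plausible span from 60000 nM to 180000 nM. For the measured compounds named here, whether the second core answers this change differently from the first rests on no measurement yet.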

Compound 4, half-maximal inhibitory concentration: 69900 nM
Compound 4: middle estimate off by 1.5-fold (0.18 log units), on the high side; measured number inside the range.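

On the core of compound 2, 4-nitrobenzyl in place of 3-bromo-4-methylphenyl on an aromatic nitrogen gives a 1.6-fold lower number from compound 2 to compound 4 (0.20 log units; within the scatter) in this assay, so the step stays inside the scatter, as the earlier step on the other core did. Set side by side, the two steps cannot be told apart: the same change on two cores in this assay, a 1.1-fold lower number (0.03 log units; within the scatter) from compound 1 to compound 3 and a 1.6-fold lower number (0.20 log units; within the scatter) from compound 2 to compound 4, 1.5-fold (0.17 log units) apart, within the scatter of two such steps. This shows that, in this assay, the change carries across these two cores without a step that can be read on either, but it does not show that the change has a real effect of any size, that the two cores answer it differently, or that the same would hold on a third core.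

The compounds shown leave open whether a longer chain, an amine or a carboxylic acid in place of these two groups on the aromatic nitrogen would move the number in this assay beyond the scatter. Also open, as far as these compounds go, is whether a methoxy group in place of the hydroxyl on the shared cores would change the read-out, or whether the step would stay as small there.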